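From compound 1 to compound 4: a methyl step

This account rests on a few compounds, and the source may have more. Where it says the series, first, only, none or still open, it means among the compounds named here.

Measured in an ADME assay on MT4 cells (Homo sapiens) for cytotoxicity, read by MTT assay, with a stated time of 5 days; on this read-out lower numbers stand for higher toxicity in this test and higher numbers for lower toxicity in this test:
compound 1 `N#Cc1ccc(Nc2nccc(OCC(=O)Nc3ccc(Cl)cc3)n2)cc1`: 162000 nM
compound 2 `N#Cc1ccc(Nc2nccc(OCC(=O)Nc3cccc(Cl)c3)n2)cc1`: > 329000 nM (a limit)
compound 3 `N#Cc1ccc(Nc2nccc(OCC(=O)Nc3ccc([N+](=O)[O-])cc3)n2)cc1`: > 320000 nM (a limit)

For the measured compounds named here, compound 1 holds the only actual number among the three, since the entries for compound 2 and compound 3 are limits. Compound 4 `Cc1cc(OCC(=O)Nc2ccc(Cl)cc2)nc(Nc2ccc(C#N)cc2)n1` changes the core of compound 1 as follows: methyl in place of hydrogen on an aromatic carbon. Going by the values given here, no measured step touches that place. The two readable steps, an at least 2.0-fold higher number from compound 1 to compound 2 (0.30 log units; that floor lies within the scatter) and an at least 1.9-fold higher number from compound 1 to compound 3 (0.29 log units; that floor lies within the scatter), both lie at the other end of the molecule, and their floors stay within the scatter. They give no ground for a large shift, so no step beyond the scatter is expected in this assay. The expected step is a 1.0-fold lower number from compound 1 to compound 4 (0.01 log units; within the scatter). For compound 4 the estimated value is 160000 nM, with an expected range of 70000 nM to 330000 nM.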

Compound 4, half-maximal cytotoxic concentration: 2630 nM
For compound 4 the middle estimate is 61-fold (1.78 log units) above the measured one; the measured number lies below the stated range.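

Methyl in place of hydrogen on an aromatic carbon, next to the ring nitrogen, gives a 62-fold lower number from compound 1 to compound 4 (1.79 log units; beyond the scatter) in this assay on the shared core. For the compounds shown here, a single added carbon at this place thus moves the read-out beyond the scatter, whereas the earlier steps, all at the other end of the molecule, had floors within it. Nothing measured here accounts for this step.

As far as these compounds go, whether the step belongs to methyl alone remains open; an ethyl chain, a methoxy group or an amine at this place would test that. Also open, from the compounds shown here alone, is whether the step persists with the 3-chlorophenyl or 4-nitrophenyl amide.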